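The compounds below may be only part of what the source reports. "The series", "measured", "known", "first", "only" and "open" are said of these compounds alone.

The measured compounds:
Compound 1, `Cc1cc(Nc2ccc(C(=O)/C=C/c3ccc4ccccc4c3)cc2)n2nc(SCc3ccc([N+](=O)[O-])cc3)nc2n1`: in a functional assay on SW-620 cells (Homo sapiens) for cytotoxicity, read by MTT assay, with stated times of 4 h and 72 h, tested at 5 uM (a higher number here means a weaker inhibitor, a lower number a stronger inhibitor), compound 1 gives 1130 nM.
Compound 2, `Cc1cc(Nc2ccc(C(=O)/C=C/c3ccc4ccccc4c3)cc2)n2nc(SCc3ccc(Br)cc3)nc2n1`: in this assay compound 2 gives 370 nM.
Compound 3, `Cc1cc(Nc2ccc(C(=O)/C=C/c3ccc4ccccc4c3)cc2)n2nc(SCc3cccc(Br)c3)nc2n1`: in this assay compound 3 gives 270 nM.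

Compound 3 holds the lowest of the three numbers. Its separation from compound 1 is clear, a 4.2-fold lower number from compound 1 to compound 3 (0.62 log units; beyond the scatter), whereas its separation from compound 2 is a 1.4-fold lower number from compound 2 to compound 3 (0.14 log units; within the scatter), so compound 3 and compound 2 cannot be told apart in this assay.

Compound 4 is `Cc1ccc(CSc2nc3nc(C)cc(Nc4ccc(C(=O)/C=C/c5ccc6ccccc6c5)cc4)n3n2)cc1`. It differs from compound 3 by 4-methylphenyl in place of 3-bromophenyl on a saturated chain carbon bound to a sulfur. Among the compounds with values here, two measured steps concern the same place. The first, a 3.1-fold lower number from compound 1 to compound 2 (0.48 log units; beyond the scatter), shows that exchanging the group on this ring can shift the number by a modest amount. The second, a 1.4-fold lower number from compound 2 to compound 3 (0.14 log units; within the scatter), shows that a change limited to the same ring can also leave the number where it was. Within the data shown here, no measured compound carries 4-methylphenyl, so the direction of the coming step is not fixed by the data. A step no larger than the modest one already seen is expected, a 1.3-fold higher number from compound 3 to compound 4 (0.11 log units; within the scatter), with the number most likely staying near compound 3. The estimate for compound 4 in this assay is 350 nM, within a range from 150 nM to 800 nM.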

Compound 4, half-maximal inhibitory concentration: 880 nM
Estimate against measurement, compound 4: 2.5-fold (0.40 log units) below; the measured number lies above the stated range.
By their numbers in this assay, from the lowest: compounds 3 and 2 (each within the scatter of the next); then compounds 4 and 1 (each within the scatter of the next).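

In this assay the ring on the saturated chain carbon bound to a sulfur proves more sensitive than the two bromo compounds alone suggested: with a 3.3-fold higher number from compound 3 to compound 4 (0.51 log units; beyond the scatter) and a 2.4-fold higher number from compound 2 to compound 4 (0.38 log units; beyond the scatter) as the measured steps, the change to 4-methylphenyl moves the number beyond the scatter, which the shift of bromo around the ring did not do. Compound 1 no longer stands alone among the higher numbers, since a 1.3-fold lower number from compound 1 to compound 4 (0.11 log units; within the scatter) leaves compound 1 and compound 4 indistinguishable, so among these four compounds the two carrying bromo hold the lower numbers, and neither the nitro nor the methyl compound goes against that. Nothing available here accounts for this difference between bromo and methyl.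

The compounds shown leave open whether chloro or fluoro on this ring would fall with the bromo compounds or with compound 1 and compound 4, and whether 3-methylphenyl would match 4-methylphenyl. They also give no reading for an amine or a carboxylic acid on this ring, or for a longer chain in place of the benzyl carbon.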